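A halogen swap on the aryl arm of a spirooxindole pair

The compounds below may be only part of what the source reports. "The series", "measured", "known", "first", "only" and "open" are said of these compounds alone.

Two closely related spiro-fused compounds have been tested in a functional assay on MCF7 cells (Homo sapiens) for antiproliferative activity, read by MTT assay, with a stated time of 48 h; a lower number here means a stronger inhibitor, a higher number a weaker inhibitor. For the measured compounds named here, compound 1, `N#CC1=C(N)Oc2c(c3nc4ccccc4nc3c3ccccc23)C12C(=O)N(Cc1cnnn1-c1ccc(S(N)(=O)=O)cc1)c1ccccc12`, is the first of them. In this assay compound 1 reaches only a limit of the assay, > 50000 nM, so no number is attached to it. Compound 2, `N#CC1=C(N)Oc2c(N)cc3nc4ccccc4nc3c2C12C(=O)N(Cc1cnnn1-c1ccccc1Cl)c1ccccc12`, carries a 2-chlorophenyl on an aromatic nitrogen of the shared core. In this assay compound 2 gives 34400 nM. This is the only actual number shown: the other result is a limit, as the limit of > 50000 nM in this assay, at which 1 of the 2 values shown sits, shows, so compound 2 cannot be placed above or below anything measured. Compound 3, `N#CC1=C(N)Oc2c(N)cc3nc4ccccc4nc3c2C12C(=O)N(Cc1cnnn1-c1c(F)cccc1F)c1ccccc12`, differs from compound 2 in a single place: 2,6-difluorophenyl in place of 2-chlorophenyl on an aromatic nitrogen. Going by the values given here, no measured pair shows what such an exchange does here, so there is no precedent to lean on. The step from compound 2 is expected to stay within the usual scatter, a 1.0-fold higher number from compound 2 to compound 3 (0.01 log units; within the scatter). Compound 3 is therefore expected to give about 35000 nM, somewhere between 12000 nM and 100000 nM.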

Compound 3, half-maximal inhibitory concentration: > 50000 nM
Compound 3: a limit, no number; the forecaster's own chance of this, stated with the estimate: 35%; middle value at least 1.4-fold (0.15 log units) away from the limit.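

In this assay, 2,6-difluorophenyl in place of 2-chlorophenyl on the aromatic nitrogen gives an at least 1.4-fold higher number from compound 2 to compound 3 (0.16 log units; that floor lies within the scatter). For the compounds shown here, this is the first exchange at this position that can be read at all, yet compound 3 carries a limit of the assay and no number, so the step has only a floor and no true size; as that floor lies within the usual scatter, the pair does not establish a real difference, although it does show that this exchange brings no lower number. With compound 3 added, compound 2 remains the only compound here with an actual number, and the rest of the series offers no further measured point for comparison: the limit of > 50000 nM in this assay, at which 2 of the 3 values shown sit.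

On these data alone, how far compound 3 truly lies from compound 2 stays unknown, and one exchange says nothing general about halogens on this aryl ring. Also open, as far as these compounds go, is how this position would respond to a plain phenyl, to a 4-methoxyphenyl, or to an aryl ring carrying an amine or a carboxylic acid, any of which could show whether a change on this arm can bring the number down.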